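The source may hold more compounds than are shown below. What is called first, only, known or untested is meant among the compounds shown, and "the series" means these compounds.

Compounds measured in a functional assay on K562 cells (Homo sapiens) for cytotoxicity, read by CCK-8 assay, with a stated time of 72 h; on this read-out higher numbers stand for weaker inhibition and lower numbers for stronger inhibition:
- compound 1 `C=CCn1c(=O)/c(=C\c2cccc(Cl)c2)[nH]c(=O)/c1=C\c1ccccc1OC` — 2700 nM
- compound 2 `COc1ccccc1/C=c1/[nH]c(=O)/c(=C\c2ccccc2OC)n(C)c1=O` — 2200 nM
- compound 3 `COc1ccccc1/C=c1/[nH]c(=O)/c(=C\c2cccc(Cl)c2Cl)[nH]c1=O` — "not active" (no number reported)

Of the two numbers reported, compound 1 has the higher one: in this assay compound 1 gives 2700 nM, while compound 2 gives 2200 nM. The gap between these two lies within the usual scatter of the method, so nothing can be said about an order between compound 1 and compound 2. For compound 3 the result is "not active" (no number reported), given without a number, and it enters no comparison.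

Compound 4 `C=CCn1c(=O)/c(=C\c2cccc(F)c2)[nH]c(=O)/c1=C\c1ccccc1OC` differs from compound 1 in a single place: fluoro in place of chloro on an aromatic carbon. No pair of measured compounds differs in just this way, so the size of the step is not known from the data shown. An exchange of one halogen for another at the same position, with no change in donors, acceptors, ring count or charge, is expected to move the number only modestly, most likely no further than the scatter, with a slight lean towards a higher number. On that basis compound 4 is estimated at 3500 nM, with a range from 1200 nM to 10000 nM. The step from compound 1 to compound 4 that this estimate implies is expected to be a 1.3-fold higher number from compound 1 to compound 4 (0.11 log units; within the scatter).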

Compound 4, half-maximal inhibitory concentration: 4100 nM
Beside the measured number, compound 4's estimate is 1.2-fold (0.07 log units) below it, within the range that was stated.
By their numbers in this assay, from the lowest: compounds 2, 1 and 4 (each within the scatter of the next).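

In this assay, going by these compounds alone, the exchange of 3-chlorophenyl for 3-fluorophenyl provides the only comparison here between compounds that differ in one place: a 1.5-fold higher number from compound 1 to compound 4 (0.18 log units; within the scatter). At this place, on an aromatic carbon meta to a large group, the step stays within the scatter, so these two halogens cannot be told apart by this read-out. No measurement shown offers an explanation for this result.

The compounds shown leave open whether an amine, a nitrile or a carboxylic acid at this place, or a plain hydrogen with no halogen at all, would give a step beyond the scatter. Also open, on these data alone, is whether the same exchange of chloro for fluoro would give a similar step on a compound other than compound 1.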